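Fixing Two Stereocentres, Same Atoms and Bonds

A few compounds are considered here, and "the series" means these few. Any claim that something is new, unique, unknown or untested is made for them only; others in the source may bear on it.

Of the compounds shown here, three have been measured in a physicochemical assay for solubility, in phosphate buffer, at pH 7.4; on this read-out higher numbers stand for higher solubility and lower numbers for lower solubility. Compound 1 `O=C(NCCCCNC(=O)NC1CC2CCC1C2)NC1CC2CCC1C2` gives 75000 nM, and compound 2 `CC1(C)C2CCC1(C)C(NC(=O)NCCCCCCCCNC(=O)NC1CC3CCC1(C)C3(C)C)C2` gives 10000 nM. Compound 3 `CC1(C)C2CCC1(C)C(NC(=O)Nc1ccccc1F)C2` stands highest of the three with 225000 nM; its nearest neighbour is compound 1, a gap beyond the scatter, while compound 2 lies furthest away, a much larger gap. Compound 4 `CC1(C)[C@@H]2CC[C@@]1(C)C(NC(=O)Nc1ccccc1F)C2` keeps every atom and bond of compound 3; the only difference is the two compounds have the same atoms and bonds; at least one stereo element is drawn with a configuration in one of them and without one in the other: 2 of 3 stereo elements differ; a stereocentre at a saturated ring carbon is drawn without a configuration in compound 3 and R in compound 4; a stereocentre at a saturated ring carbon is drawn without a configuration in compound 3 and R in compound 4. Among the measured compounds shown here, since nothing leaves or enters and only two stereocentres become definite in the drawing, nothing among the measured compounds points to a shift, so the expected step from compound 3 to compound 4 is no change at the digits printed from compound 3 to compound 4 (within the scatter), none beyond the scatter. Compound 4 is therefore estimated at 225000 nM, within a range from 110000 nM to 450000 nM.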

Compound 4, solubility: 225000 nM
Compound 4: middle estimate and measured number agree at the digits printed; measured number inside the range.
By their numbers in this assay, from the lowest: compound 2; then compound 1; then compounds 3 and 4 (each within the scatter of the next).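

Here this assay shows no change at the digits printed from compound 3 to compound 4 (within the scatter) and so offers the first comparison of two compounds that differ in one place. Making these two stereocentres definite in the drawing leaves the solubility reading unmoved, something the earlier compounds, which differ in several places at once, could not show. The comparison rests on one difference alone: the fact that one of compounds 3 and 4 is drawn with a defined configuration and the other without, at the place where they differ.

Still open, as far as these compounds go, is whether the opposite configuration at these stereocentres would read the same. Also open, from the compounds shown here alone, is whether a carboxylic acid or an amine in place of the fluorine would shift the number.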